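This account rests on a few compounds, and the source may have more. Where it says the series, first, only, none or still open, it means among the compounds named here.

Measured compounds:
Compound 1, `COc1ncnc2c1c(-c1ccoc1)cn2[C@@H]1O[C@H](CO)[C@@H](O)[C@H]1O`: in a functional assay on K562 cells (Homo sapiens), read by MTT assay, with a stated time of 72 h (on this read-out higher numbers stand for weaker inhibition and lower numbers for stronger inhibition), compound 1 gives 2820 nM.
Compound 2, `COc1ncnc2c1c(-c1cccs1)cn2[C@@H]1O[C@H](CO)[C@@H](O)[C@H]1O`: in this assay compound 2 gives 6200 nM.
Compound 3, `CSc1ncnc2c1c(-c1cccs1)cn2[C@@H]1O[C@H](CO)[C@@H](O)[C@H]1O`: in this assay compound 3 reaches only a limit of the assay, > 20000 nM.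

Compound 2 holds the highest of the two numbers; its nearest neighbour is compound 1, and the step of a 2.2-fold higher number from compound 1 to compound 2 (0.34 log units; beyond the scatter) is modest, coming with thiophen-2-yl in place of furan-3-yl on an aromatic carbon. The other step, an at least 3.2-fold higher number from compound 2 to compound 3 (0.50 log units; beyond the scatter), ends at the limit of > 20000 nM in this assay, at which 1 of the 3 values shown sits, and concerns methylsulfanyl in place of methoxy, a different part of the core, so it does not bear on what follows.

Compound 4, `COc1ncnc2c1c(-c1cc3ccccc3o1)cn2[C@@H]1O[C@H](CO)[C@@H](O)[C@H]1O`, is not yet measured. The change is 1-benzofuran-2-yl in place of thiophen-2-yl on an aromatic carbon. For the measured compounds named here, only the step from compound 1 to compound 2 touches the same aromatic carbon, and it was modest; nothing measured speaks to the added six-membered aromatic ring of carbon only. No step beyond the scatter is therefore expected: compound 4 is estimated at 4500 nM, with a range from 1500 nM to 14000 nM. The expected step is a 1.4-fold lower number from compound 2 to compound 4 (0.14 log units; within the scatter).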

Compound 4, half-maximal inhibitory concentration: 13100 nM
Estimate against measurement, compound 4: 2.9-fold (0.46 log units) below, within the range that was stated.
By their numbers in this assay, from the lowest: compound 1; then compound 2; then compound 4. At a limit, above all of these: compound 3.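

At this aromatic carbon, a group carrying an added six-membered aromatic ring of carbon only brings no gain in this assay: a 2.1-fold higher number from compound 2 to compound 4 (0.32 log units; beyond the scatter), and a 4.6-fold higher number from compound 1 to compound 4 (0.67 log units; beyond the scatter). Among the compounds with methoxy on the core, the three groups at this carbon are thus separated beyond the scatter, with furan-3-yl giving the lowest number and 1-benzofuran-2-yl the highest. Nothing shown gives a cause for these steps.

1-Benzofuran-2-yl differs from thiophen-2-yl in both its hetero atom and the added ring, and furan-2-yl or 1-benzothiophen-2-yl would be needed to separate the two changes. Also open, on these data alone, are how a plain phenyl or a thiophene carrying an aminomethyl group would read at this carbon, and whether the order of the groups holds with methylsulfanyl in place of methoxy.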